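Swapping an oxolane for a dioxolane under cytotoxicity testing

A few compounds are considered here, and "the series" means these few. Any claim that something is new, unique, unknown or untested is made for them only; others in the source may bear on it.

For the measured compounds named here, in a toxicity assay on L02 cells (Homo sapiens) for cytotoxicity, read by MTT assay, with a stated time of 72 h (a lower number here means a stronger inhibitor, a higher number a weaker inhibitor), compound 1 `O=C1c2c[n+]([O-])c3ccccc3c2C(=O)c2c1c1ccccc1n2Cc1cn([C@H]2O[C@H](CO)[C@@H](O)[C@H]2O)nn1` gives 950 nM and so shares the upper end of the numbers so far with compound 3 `O=C1c2c[n+]([O-])c3ccccc3c2C(=O)c2c1c1ccccc1n2CCN1CCCC1` at 930 nM as these two values lie within the scatter of each other. Compound 2 `CN1CCN(CCCCn2c3c(c4ccccc42)C(=O)c2c[n+]([O-])c4ccccc4c2C3=O)CC1` stands apart at 80 nM with a clearly lower number than either of them.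

Compound 4 `CC1(C)O[C@@H](CO)[C@H](Cn2cc(Cn3c4c(c5ccccc53)C(=O)c3c[n+]([O-])c5ccccc5c3C4=O)nn2)O1` has yet to be measured. Its change from compound 1 is counted as follows: (5-(hydroxymethyl)-2,2-dimethyl-1,3-dioxolan-4-yl)methyl in place of 3,4-dihydroxy-5-(hydroxymethyl)oxolan-2-yl on an aromatic nitrogen while the shared core stays as it is. The group (5-(hydroxymethyl)-2,2-dimethyl-1,3-dioxolan-4-yl)methyl takes the place of 3,4-dihydroxy-5-(hydroxymethyl)oxolan-2-yl on an aromatic nitrogen of a five-membered aromatic ring with 3 nitrogen.

Going by the values given here, no measured step touches this group. The only one available is a 12-fold higher number from compound 2 to compound 3 (1.07 log units; beyond the scatter) which is large but concerns a different substituent. It gives no direction for this change and serves only as a reason to keep the range wide. No step beyond the scatter is therefore expected, and the estimated step is a 1.3-fold lower number from compound 1 to compound 4 (0.10 log units; within the scatter) with no firm direction behind it. In this assay compound 4 is estimated at 750 nM with an expected range of 250 nM to 2200 nM for now.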

Compound 4, half-maximal inhibitory concentration: 500 nM
Compound 4: the middle estimate sits 1.5-fold (0.18 log units) above what was measured, within the range that was stated.
By their numbers in this assay, from the lowest: compound 2; then compounds 4, 3 and 1 (each within the scatter of the next).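

In this assay, the position on the aromatic nitrogen of the five-membered aromatic ring with 3 nitrogen now has its first reading: the exchange of 3,4-dihydroxy-5-(hydroxymethyl)oxolan-2-yl for (5-(hydroxymethyl)-2,2-dimethyl-1,3-dioxolan-4-yl)methyl gives a 1.9-fold lower number from compound 1 to compound 4 (0.28 log units; within the scatter). This position therefore accepted a change from 3 hydrogen-bond donors to 1, and from 4 defined stereocentres to 2, without a step beyond the scatter, so the pair gives no firm direction for this change. Nothing available explains the result or ties it to any one part of the exchange.

The ring, the hydroxyl groups, the methyl groups and the stereocentres all change together in this pair, so the compounds shown cannot separate what each contributes. From the compounds shown here alone, it also remains open how this assay would read with a group of another kind on the same nitrogen, such as a primary amine, a carboxylic acid or a longer open chain ending in a hydroxyl group.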